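Flipping One Ring Stereocentre in a Weak Cytotoxic Ester

This account rests on a few compounds, and the source may have more. Where it says the series, first, only, none or still open, it means among the compounds named here.

Measured so far:
compound 1, `COc1ccc(C(=O)O[C@H]2CC(C)=C[C@@H](OC(C)=O)[C@@]3(C)[C@@H](OC(C)=O)C[C@@](O)(C(C)C)[C@H]23)cc1` — 42900 nM
compound 2, `COc1ccc(C(=O)O[C@H]2CC(C)=C[C@@H](O)[C@@]3(C)[C@@H](OC(C)=O)C[C@@](O)(C(C)C)[C@H]23)cc1` — 70400 nM

In a functional assay on RS4-11 cells (Homo sapiens) for cytotoxicity, read by MTT assay, with a stated time of 72 h (a higher number here means a weaker inhibitor, a lower number a stronger inhibitor), compound 1 gives 42900 nM, the lowest of the two numbers; its nearest neighbour is compound 2, and the step of a 1.6-fold higher number from compound 1 to compound 2 (0.22 log units; within the scatter) shows hydrogen in place of acetyl on an oxygen on a saturated carbon, a change that stays within the scatter.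

Compound 3, `COc1ccc(C(=O)O[C@H]2CC(C)=C[C@H](OC(C)=O)[C@@]3(C)[C@@H](OC(C)=O)C[C@@](O)(C(C)C)[C@H]23)cc1`, has not been measured yet. It differs from compound 1 as follows: the two compounds have the same atoms and bonds and differ only in configuration as drawn: 1 of 6 stereo elements differ; a stereocentre at a saturated ring carbon is drawn R in compound 1 and S in compound 3.

Going by the values given here, neither of the two measured compounds offers a step of this kind, so no measured step bears on this change. Among the compounds with values here, the only step available, from compound 1 to compound 2, is within the scatter and concerns a different part of the core, so it says nothing about a change of configuration. With no guide from the data, the expectation is that compound 3 will sit near compound 1, with no step beyond the scatter, though a change of configuration at a ring carbon could move the number in either direction. Compound 3 is therefore expected to give about 45000 nM, within a range from 15000 nM to 135000 nM, which means an expected step of a 1.0-fold higher number from compound 1 to compound 3 (0.02 log units; within the scatter).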

Compound 3, half-maximal inhibitory concentration: 2800 nM
Compound 3: middle estimate off by 16-fold (1.21 log units), on the high side, and the stated range ends above it.
By their numbers in this assay, from the lowest: compound 3; then compounds 1 and 2 (each within the scatter of the next).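

In this assay, turning a single stereocentre at a saturated ring carbon from R, as drawn in compound 1, to S, as drawn in compound 3, gives a 15-fold lower number from compound 1 to compound 3 (1.19 log units; beyond the scatter), so the three-dimensional arrangement at this carbon has a large effect on the number even though the drawn atoms and bonds stay the same. Going by these compounds alone, the only earlier comparison, a 1.6-fold higher number from compound 1 to compound 2 (0.22 log units; within the scatter), showed no change beyond the scatter, which left open whether any single change to this core could shift the number much; this step is the first to do so. The shift can be put down to configuration alone because nothing else separates the pair: the fact that compounds 1 and 3 differ only in the configuration as drawn.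

What the S configuration does in cells remains unexplained, since a single pair of compounds shows that the arrangement matters but gives no reason for it. It is also unknown whether the lower number would persist with hydrogen in place of acetyl on the same scaffold, with a longer chain such as butanoyl in place of an acetyl group, or with an amine in place of the methoxy group.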